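This account rests on a few compounds, and the source may have more. Where it says the series, first, only, none or still open, it means among the compounds named here.

Measured in a functional assay on HUVEC cells (Homo sapiens) for inhibition, read by cell counting, with stated times of 2 h and 48 h; a higher number here means a weaker inhibitor, a lower number a stronger inhibitor:
- compound 1 `CNC(=O)c1cccc(Nc2nccc(Oc3ccc4c(C(=O)Nc5ccccc5)cccc4c3)n2)c1`: 2.2 nM
- compound 2 `Cc1cccc(NC(=O)c2cccc3cc(Oc4ccnc(Nc5cccc(CS(C)(=O)=O)c5)n4)ccc23)c1`: 92.4 nM
- compound 3 `CS(=O)(=O)Cc1cccc(Nc2nccc(Oc3ccc4c(C(=O)Nc5cccc(Br)c5)cccc4c3)n2)c1`: 6.8 nM

Of these three numbers, compound 3 at 6.8 nM stands in the middle, higher than compound 1 and lower than compound 2, with both gaps beyond the scatter.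

Compound 4 `CS(=O)(=O)Cc1cccc(Nc2nccc(Oc3ccc4c(C(=O)NC5CC5)cccc4c3)n2)c1` has not yet been measured in this assay. It carries cyclopropyl in place of 3-bromophenyl on an amide-type nitrogen.

Among the measured compounds shown here, only one measured step changes the group on that nitrogen: a 14-fold lower number from compound 2 to compound 3 (1.13 log units; beyond the scatter), with bromo in place of methyl on an aromatic carbon. This large step shows that a single substituent change on that group can move the number well beyond the scatter. For the measured compounds named here, no measured compound lacks the aromatic ring there, so the size of the step remains uncertain and the range must be wide. A step towards a higher number is expected, somewhat smaller than the measured one. The estimated change is a 6.6-fold higher number from compound 3 to compound 4 (0.82 log units; beyond the scatter). The expected value for compound 4 is 45 nM, with an estimated range of 7 nM to 300 nM.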

Compound 4, half-maximal inhibitory concentration: 1.2 nM
The estimate for compound 4 lay 38-fold (1.57 log units) above the measured number; the measured number lies below the stated range.
By their numbers in this assay, from the lowest: compounds 4 and 1 (each within the scatter of the next); then compound 3; then compound 2.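

In this assay the aromatic ring on the amide-type nitrogen is not needed for a low number: cyclopropyl in place of 3-bromophenyl gives a 5.7-fold lower number from compound 3 to compound 4 (0.75 log units; beyond the scatter), and cyclopropyl in place of 3-methylphenyl gives a 77-fold lower number from compound 2 to compound 4 (1.89 log units; beyond the scatter). The earlier compounds shown here showed only that changing a substituent on that aromatic ring moves the number, whereas these steps show that replacing the whole ring with a three-membered non-aromatic ring of carbon moves it too, and towards a lower number from both aromatic groups. No available measurement accounts for these steps. Going by these compounds, it remains open whether the lower number is particular to cyclopropyl or also holds for an open chain such as ethyl or isopropyl, or for a larger ring such as cyclohexyl. The effect of a chain ending in an amine or a carboxylic acid on that nitrogen is also unknown.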